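The compounds below may be only part of what the source reports. "The series", "measured", "known", "first", "only" and "open" are said of these compounds alone.

Compound 3 `CC1=NC(C)=C([N+](=O)[O-])C(c2cccnc2)/C1=C(\O)OC1CCCC1` gives 3280 nM in a functional assay (cardiac atrium) for agonist activity, with Cavia porcellus as the target; on this read-out higher numbers stand for an effect only at larger amounts of compound and lower numbers for an effect already at smaller amounts. Among the three measured compounds it stands second highest. Its nearest neighbour is compound 1 `CC1=NC(C)=C([N+](=O)[O-])C(c2cccnc2)/C1=C(\O)OC1CCCCC1`, which gives 2760 nM; the difference, a 1.2-fold higher number from compound 1 to compound 3 (0.07 log units; within the scatter), is within the scatter. Furthest away is compound 2 `CC1=NC(C)=C([N+](=O)[O-])C(c2cccnc2)/C1=C(\O)OC(C)C`, which gives 28500 nM; here the step of an 8.7-fold lower number from compound 2 to compound 3 (0.94 log units; beyond the scatter) is beyond the scatter.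

Compound 4 `CO/C(O)=C1\C(C)=NC(C)=C([N+](=O)[O-])C1c1cccnc1` differs from compound 3 in one place: methyl in place of cyclopentyl on an oxygen on an unsaturated carbon. Within the data shown here, two measured steps bear on this change, both at the same place on the shared core. Going to a smaller, open-chain group gave a 10-fold higher number from compound 1 to compound 2 (1.01 log units; beyond the scatter), and going back to a ring gave an 8.7-fold lower number from compound 2 to compound 3 (0.94 log units; beyond the scatter). Methyl is smaller still than isopropyl, so a shift towards a higher number, beyond the scatter, is expected for compound 4, though how much further than isopropyl cannot be read from these three compounds. Compound 4 is therefore estimated at 40000 nM, within a range of 10000 nM to 160000 nM. That estimate means an expected step of a 12-fold higher number from compound 3 to compound 4 (1.09 log units; beyond the scatter).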

Compound 4, half-maximal effective concentration: 70000 nM
Compound 4: middle estimate off by 1.8-fold (0.24 log units), on the low side; measured number inside the range.
By their numbers in this assay, from the lowest: compounds 1 and 3 (each within the scatter of the next); then compound 2; then compound 4.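

In this assay, methyl stands well apart from both ring groups, with a 21-fold higher number from compound 3 to compound 4 (1.33 log units; beyond the scatter) and a 25-fold higher number from compound 1 to compound 4 (1.40 log units; beyond the scatter). Shrinking the group on this oxygen from isopropyl to methyl still raises the number, with a 2.5-fold higher number from compound 2 to compound 4 (0.39 log units; beyond the scatter), so across these four compounds a smaller group goes with a higher number, though this last step is smaller than the one from a ring to isopropyl, a 10-fold higher number from compound 1 to compound 2 (1.01 log units; beyond the scatter). Nothing measured here offers an explanation for this trend.

On these data alone, it remains open whether ring and open-chain groups of similar size behave alike, which a pentyl group compared with cyclopentyl would test. It is also unclear whether the number falls further with a larger group, such as benzyl or a longer chain, or stays level, as cyclopentyl and cyclohexyl do.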